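Thioether variation on the shared core: outlook for compound 3

A few compounds are considered here, and "the series" means these few. Any claim that something is new, unique, unknown or untested is made for them only; others in the source may bear on it.

Compound 1 `Cc1cc(N2CC[C@@H](C)[C@@H](N(C)c3ncnc4[nH]ccc34)C2)n2nc(SCCCc3ccccc3)nc2n1`: > 100000 nM
Compound 2 `Cc1cc(N2CC[C@@H](C)[C@@H](N(C)c3ncnc4[nH]ccc34)C2)n2nc(SCc3csc4ccc(Cl)cc34)nc2n1`: > 100000 nM

In a functional assay on BGC-823 cells (Homo sapiens) for inhibition, read by MTT assay, with a stated time of 72 h (on this read-out lower numbers stand for stronger inhibition and higher numbers for weaker inhibition), compound 1 reaches only the limit of the assay, > 100000 nM. Compound 2 likewise stands at the limit, > 100000 nM. The step that the two limits leave unreadable from compound 1 to compound 2 thus cannot be read as a number; both values rest on (the limit of > 100000 nM in this assay, at which 2 of the 2 values shown sit). Compound 3 `Cc1cc(N2CC[C@@H](C)[C@@H](N(C)c3ncnc4[nH]ccc34)C2)n2nc(SCc3ccc(F)cc3)nc2n1` differs from compound 2 by 4-fluorophenyl in place of 5-chloro-1-benzothiophen-3-yl on a saturated chain carbon bound to a sulfur. For the measured compounds named here, no measured step gives a usable size, so the expected step of a number no higher from compound 2 to compound 3 (the limit leaves the size open) is taken as none beyond the scatter, with a further limit the likely report. Compound 3 is estimated at 100000 nM, between 30000 nM and 300000 nM.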

Compound 3, half-maximal inhibitory concentration: 44300 nM
Beside the measured number, compound 3's estimate is 2.3-fold (0.35 log units) above it; the measured number falls inside the stated range.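

At this position, on a saturated chain carbon bound to a sulfur, 4-fluorophenyl moves the series off the limit in this assay, with an at least 2.2-fold lower number from compound 2 to compound 3 (0.35 log units; beyond the scatter) and an at least 2.2-fold lower number from compound 1 to compound 3 (0.35 log units; beyond the scatter). So this position can change the read-out, though compound 3 remains a weak inhibitor at 44300 nM. Both steps are bounds and not true sizes: the limit of > 100000 nM in this assay, at which 2 of the 3 values shown sit.

Whether the fluorine contributes to the step remains open, since plain benzyl does not appear among these compounds. So does the effect of an amine or a carboxylic acid on the 4-position of that phenyl ring.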